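The compounds below may be only part of what the source reports. "The series", "measured", "known", "first", "only" and "open" are said of these compounds alone.

Going by the values given here, compound 2 `CN1CCN(CC(=O)Nc2ccc(-c3nc(-c4ccccc4)c(-c4ccccc4)n3C)cc2)CC1` gives 35.5 ug/mL in a functional assay on HT-29 cells (Homo sapiens) for cytotoxicity, read by MTT assay, with a stated time of 24 h (a lower number here means a stronger inhibitor, a higher number a weaker inhibitor), the higher of the two numbers measured so far; its nearest neighbour, compound 1 `Cn1nnnc1SCC(=O)Nc1ccc(-c2nc(-c3ccccc3)c(-c3ccccc3)n2C)cc1`, gives 1.6 ug/mL, and a 22-fold higher number from compound 1 to compound 2 (1.35 log units; beyond the scatter). Compound 3 `Cn1c(-c2ccc(NC(=O)CN3CCN(Cc4ccc(Cl)cc4)CC3)cc2)nc(-c2ccccc2)c1-c1ccccc1` differs from compound 2 by 4-chlorophenyl in place of hydrogen on a saturated chain carbon bound to an amine nitrogen in a ring. Among the compounds with values here, the single measured step altered a different part of the molecule, the group on the saturated chain carbon bound to the carbonyl carbon, so no measured step bears directly on this change. Compound 3 is therefore expected to give 10 ug/mL, within 3 ug/mL to 40 ug/mL, which would mean an expected 3.6-fold lower number from compound 2 to compound 3 (0.55 log units; beyond the scatter).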

Compound 3, half-maximal inhibitory concentration: 12 ug/mL
Compound 3: middle estimate off by 1.2-fold (0.08 log units), on the low side; measured number inside the range.
By their numbers in this assay, from the lowest: compound 1; then compound 3; then compound 2.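

In this assay, the step shows that the far end of the 4-methylpiperazin-1-yl group also affects the number: 4-chlorophenyl in place of hydrogen on the saturated chain carbon bound to an amine nitrogen in a ring gives a 3.0-fold lower number from compound 2 to compound 3 (0.47 log units; beyond the scatter). The earlier step had replaced the whole group on the carbon bound to the carbonyl carbon, whereas this one keeps that group and extends it. Nothing available explains the shift. The compounds shown leave open whether a plain benzyl, a 4-fluorobenzyl or a longer alkyl chain would give a similar number here.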